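A few compounds are considered here, and "the series" means these few. Any claim that something is new, unique, unknown or untested is made for them only; others in the source may bear on it.

Measured so far:
- compound 1, `COC(=O)/C=C/c1cccc(N(Cc2ccc(C(C)(C)C)cc2)C(=O)C2CCCCC2)c1`, > 1000 nM
- compound 2, `CCOC(=O)/C=C/c1ccc(CN(C(=O)C2CCCCC2)c2cccc(/C=C/C(=O)OC)c2)cc1`, > 1000 nM

Both measured compounds share a core carrying a cyclohexanecarbonyl amide and a methyl cinnamate arm; they differ only in the group on the benzyl ring. In an assay on isolated protein with Bile acid receptor (Homo sapiens) as the target (a lower number here means that less compound is needed, a higher number that more compound is needed for the effect), compound 1 reaches only the assay limit, > 1000 nM, so it is not a measured number. In this assay compound 2 likewise sits at the limit, > 1000 nM. Among the compounds with values here, the one measured step, a step that the two limits leave unreadable from compound 1 to compound 2, therefore cannot be read in size or direction, since (the limit of > 1000 nM in this assay, at which 2 of the 2 values shown sit).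

Compound 3, `COC(=O)/C=C/c1cccc(N(Cc2ccc(-c3ccc(OC(F)(F)F)cc3)cc2)C(=O)C2CCCCC2)c1`, is not yet measured. It differs from compound 2 by 4-(trifluoromethoxy)phenyl in place of 2-(ethoxycarbonyl)ethenyl on an aromatic carbon. Within the data shown here, no measured step bears on this change, because the only step available is itself unreadable a step that the two limits leave unreadable from compound 1 to compound 2. The expectation for compound 3 can thus rest only on the two limits, which give no slope to follow. Compound 3 is expected to land near the same limit, estimated at 1500 nM in this assay, with a likely range from 300 nM to 8000 nM. The step this estimate implies, a step that the limit leaves unreadable from compound 2 to compound 3, is an expectation with wide uncertainty, and a reading at the limit again is considered more likely than not.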

Compound 3, half-maximal effective concentration: 264 nM
The estimate for compound 3 lay 5.7-fold (0.75 log units) above the measured number; the whole stated range lies above it.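

With 4-(trifluoromethoxy)phenyl on this aromatic carbon, para to a large group, the series gives its first read-out in this assay that is an actual number rather than a limit, so the group at this position can shift the result. The change brings an at least 3.7-fold lower number from compound 2 to compound 3 (0.57 log units; beyond the scatter), and the same group in place of tert-butyl brings an at least 3.7-fold lower number from compound 1 to compound 3 (0.57 log units; beyond the scatter). Both steps are beyond the usual scatter, but they give only minimum sizes, and the step between compound 1 and compound 2 cannot be read at all, because the earlier compounds give only a limit: the limit of > 1000 nM in this assay, at which 2 of the 3 values shown sit.

The compounds shown do not separate the contribution of the added aromatic ring from that of the trifluoromethoxy group at its end, a question that a plain phenyl, a 4-methoxyphenyl or a 4-chlorophenyl group at the same position could address. They also leave open how the read-out responds to changes elsewhere in the shared core, such as a carboxylic acid in place of the methyl ester or another acyl group in place of the cyclohexanecarbonyl amide.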